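Dimethylamino purine benzyl series: fluoro for methyl

A few compounds are considered here, and "the series" means these few. Any claim that something is new, unique, unknown or untested is made for them only; others in the source may bear on it.

Compound 1 `Cc1cccc(Cn2cnc3c(N(C)C)ncnc32)c1` carries a methyl on the benzyl ring. In a functional assay on the whole organism with Rattus norvegicus as the target, in the maximal electroshock model (a lower number here means that less compound is needed, a higher number that more compound is needed for the effect), compound 1 gives 25 mg/kg. Compound 2 `CN(C)c1ncnc2c1ncn2Cc1cccc(F)c1` has fluoro in its place, described as fluoro in place of methyl on an aromatic carbon; in this assay compound 2 gives 8.4 mg/kg, which is a 3.0-fold lower number from compound 1 to compound 2 (0.47 log units; beyond the scatter).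

Compound 3 `Cc1ccccc1Cn1cnc2c(N(C)C)ncnc21` is built from the same atoms as compound 1, joined differently; the difference between the two cores is not broken down here. In this assay compound 3 gives 9 mg/kg, within the scatter of compound 2 and a higher number than compound 1.

Compound 4 `CN(C)c1ncnc2c1ncn2Cc1ccccc1F` is not yet measured. It differs from compound 3 by fluoro in place of methyl on an aromatic carbon. This is the same kind of change as from compound 1 to compound 2, but the place differs: there the fluoro sat meta to a large group, here it sits ortho to a large group. Among the measured compounds shown here, only the one measured step exists for this change, so an expectation of a 2.0-fold lower number from compound 3 to compound 4 (0.30 log units; within the scatter) is taken, somewhat smaller than a 3.0-fold lower number from compound 1 to compound 2 (0.47 log units; beyond the scatter), resting on that single pair. Compound 4 is therefore estimated at 4.5 mg/kg in this assay, with an expected range from 2.5 mg/kg to 10 mg/kg.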

Compound 4, dose for half-maximal effect: 8.8 mg/kg
Compound 4: middle estimate off by 2.0-fold (0.29 log units), on the low side, within the range that was stated.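

In this assay, fluoro in place of methyl on an aromatic carbon does not behave the same way on the two cores: the same change on two cores in this assay, a 3.0-fold lower number (0.47 log units; beyond the scatter) from compound 1 to compound 2 and a 1.0-fold lower number (0.01 log units; within the scatter) from compound 3 to compound 4, 2.9-fold (0.46 log units) apart, beyond the scatter of two such steps

With the group ortho to a large group, the change gives a 1.0-fold lower number from compound 3 to compound 4 (0.01 log units; within the scatter), so the clear step seen on the core of compound 1 does not carry over to the core of compound 3. This does not show why the two steps differ, and two pairs give no rule for predicting the size of this change on any further core in the series.

The compounds shown leave open how a chloro, methoxy or trifluoromethyl group on the same ring would compare with methyl and fluoro on either core. They also leave open how this assay would respond if the dimethylamino group were replaced by another amine or a longer chain.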